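The source may hold more compounds than are shown below. What is called first, only, known or untested is meant among the compounds shown, and "the series" means these compounds.

Compound 1 `Nc1ccc2oc(-c3cccc(F)c3)c(O)c(=O)c2c1` carries a fluoro group on an aromatic carbon. In an ADME assay on MT4 cells (Homo sapiens) for cytotoxicity, read by MTT assay, with a stated time of 4 days (on this read-out higher numbers stand for lower toxicity in this test and lower numbers for higher toxicity in this test), compound 1 gives 35300 nM. Compound 2 `Nc1ccc2oc(-c3cccc(C(F)(F)F)c3)c(O)c(=O)c2c1` differs from it by trifluoromethyl in place of fluoro on an aromatic carbon and in this assay compound 2 gives 8100 nM. Taken together these two values make a 4.4-fold lower number from compound 1 to compound 2 (0.64 log units; beyond the scatter). Compound 3 `COc1c(-c2cccc(F)c2)oc2ccc(NC(C)=O)cc2c1=O` is built on a different core; how the core of compound 3 differs from the core of compound 1 is not broken down here. In this assay compound 3 gives 210000 nM, the highest of the three numbers, with the gap to compound 1 beyond the scatter and the wider gap to compound 2 beyond it as well. Compound 4 `COc1c(-c2cccc(C(F)(F)F)c2)oc2ccc(NC(C)=O)cc2c1=O` has not been measured. It is related to compound 3 by trifluoromethyl in place of fluoro on an aromatic carbon, the same change as that from compound 1 to compound 2. The change is expected to carry over roughly as the estimated step of a 3.8-fold lower number from compound 3 to compound 4 (0.58 log units; beyond the scatter), though with wide room for error because a 4.4-fold lower number from compound 1 to compound 2 (0.64 log units; beyond the scatter) rests on one pair and one core only. Compound 4 is therefore estimated at 55000 nM, with a range from 20000 nM to 150000 nM.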

Compound 4, half-maximal cytotoxic concentration: 201000 nM
Estimate against measurement, compound 4: 3.7-fold (0.56 log units) below, and the stated range ends below it.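

In this assay, trifluoromethyl in place of fluoro on an aromatic carbon gives a 1.0-fold lower number from compound 3 to compound 4 (0.02 log units; within the scatter). Set beside the earlier step, the same change did not carry over in size from the core of compound 1 to the core of compound 3: the same change on two cores in this assay, a 4.4-fold lower number (0.64 log units; beyond the scatter) from compound 1 to compound 2 and a 1.0-fold lower number (0.02 log units; within the scatter) from compound 3 to compound 4, 4.2-fold (0.62 log units) apart, beyond the scatter of two such steps

This shows that, for these two pairs, the size of the step depends on the core that carries it, so a value from one core is a poor guide to the other; it does not show which feature of the two cores accounts for the gap, and two pairs give no rule for any third core.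

The compounds shown leave open whether other groups on the same aromatic carbon, such as chloro, methyl or nitrile, would behave as they do on the core of compound 1 or on that of compound 3. They also leave open how the change would fare on a core combining the amine of compound 1 with the methoxy group of compound 3.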